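Thiazolidinedione amides on the shared core: piperidine variant

The source may report more compounds than this note shows. Statements on the series, on what has been measured and on what is new or still open speak of the compounds shown alone.

Measured so far:
compound 1 `Cn1c(/C=C2\SC(=O)N(CC(=O)Nc3cc(C(C)(C)C)on3)C2=O)nc2ccccc21` — 33800 nM
compound 2 `CCn1c(/C=C2\SC(=O)N(CC(=O)N3CCOCC3)C2=O)nc2ccccc21` — > 50000 nM

For the measured compounds named here, in a functional assay on MDA-MB-231 cells (Homo sapiens) for inhibition, read by MTT assay, with a stated time of 48 h (on this read-out higher numbers stand for weaker inhibition and lower numbers for stronger inhibition), compound 1 gives 33800 nM, the only numeric value in the set. Compound 2 gives > 50000 nM, which is a limit of the assay rather than a number; this limit is the one described as the limit of > 50000 nM in this assay, at which 1 of the 2 values shown sits. No step between measured compounds is shown, and nothing is shown on how compound 2 relates to compound 1 beyond the two values themselves.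

Compound 3 `Cn1c(/C=C2\SC(=O)N(CC(=O)N3CCCCC3)C2=O)nc2ccccc21` is not yet measured in this assay. It differs from compound 1 by piperidin-1-yl in place of (5-(tert-butyl)-1,2-oxazol-3-yl)amino on a carbonyl carbon. Going by the values given here, with no measured step to rest on, the expectation for this change is a move toward weaker inhibition, of a size that may exceed the scatter, given that compound 2 with a related amide reaches > 50000 nM. Compound 3 is therefore estimated at 45000 nM (range 15000 nM to 120000 nM), which means an expected step of a 1.3-fold higher number from compound 1 to compound 3 (0.12 log units; within the scatter).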

Compound 3, half-maximal inhibitory concentration: > 50000 nM
Compound 3 was reported as a limit (the forecaster's own chance of this, stated with the estimate: 45%); middle value at least 1.1-fold (0.04 log units) from the limit.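

In this assay compound 3 gives > 50000 nM, which is a limit of the assay and not a number. Piperidin-1-yl in place of (5-(tert-butyl)-1,2-oxazol-3-yl)amino on the carbonyl carbon gives the first step in the series, an at least 1.4-fold higher number from compound 1 to compound 3 (0.17 log units; that floor lies within the scatter); this is only a floor and it lies within the scatter, so the true size of the change remains unknown and no loss of inhibition beyond the scatter can be stated. Compound 1 alone carries a number so far, and the limit is now shared: the limit of > 50000 nM in this assay, at which 2 of the 3 values shown sit.

Still open, as far as these compounds go, is which part of the departing group matters: the oxazole ring, the tert-butyl group or the amide hydrogen, all of which leave together in this change. A phenylamino group on the same carbonyl carbon, or the oxazolylamino group without its tert-butyl, would separate these parts.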